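This account rests on a few compounds, and the source may have more. Where it says the series, first, only, none or still open, it means among the compounds named here.

Compound 1 `O=C(c1cccc(Nc2ncc(F)c(Nc3ccc(F)cc3)n2)c1)N1CCCCC1` gives 13000 nM in a functional assay on DU-145 cells (Homo sapiens) for antiproliferative activity, read by sulforhodamine B assay, with a stated time of 3 days; a higher number here means a weaker inhibitor of growth, a lower number a stronger inhibitor of growth. Compound 2 `COc1ccc(N2CCN(C)CC2)cc1Nc1ncc(F)c(Nc2ccc(F)cc2)n1` gives 910 nM. Compound 3 `COc1ccc(NC(=O)c2cccc(Nc3ncc(F)c(Nc4ccc(F)cc4)n3)c2)cc1` gives only a limit, > 10000 nM, and no number.

Compound 3 therefore stands at the edge of what this assay can report: the limit of > 10000 nM in this assay, at which 1 of the 3 values shown sits. The change to compound 4 `O=C(Nc1ccccn1)c1cccc(Nc2ncc(F)c(Nc3ccc(F)cc3)n2)c1` is pyridin-2-yl in place of 4-methoxyphenyl on an amide-type nitrogen. For the measured compounds named here, the one measured step that touches this position, a step that the limit leaves unreadable from compound 1 to compound 3, is itself hidden by the limit, and no measured pair shows pyridin-2-yl in place of 4-methoxyphenyl. Compound 1, with piperidin-1-yl on the carbonyl carbon, is also a weak inhibitor. The expected step that the limit leaves unreadable from compound 3 to compound 4 is therefore small, without a clear direction. Compound 4 is estimated at 15000 nM, between 5000 nM and 50000 nM, and may again be reported only as a limit.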

Compound 4, concentration for 50% growth inhibition: 15100 nM
Compound 4: the middle estimate sits 1.0-fold (0.00 log units) below what was measured; the measured number falls inside the stated range.
By their numbers in this assay, from the lowest: compound 2; then compounds 1 and 4 (each within the scatter of the next).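

Unlike compound 3, compound 4 gives a readable number, so this position now has its first measured step. In this assay, (pyridin-2-yl)amino in place of piperidin-1-yl on a carbonyl carbon gives a 1.2-fold higher number from compound 1 to compound 4 (0.07 log units; within the scatter), so these two groups cannot be told apart here. The step from compound 3 to compound 4 cannot be read because compound 3 carries only a limit: the limit of > 10000 nM in this assay, at which 1 of the 4 values shown sits.

As far as these compounds go, it remains open whether a carboxylic acid or a dimethylaminoethyl chain on the amide-type nitrogen would shift the number. The compounds shown give no answer.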